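The source may hold more compounds than are shown below. What is called first, only, known or untested is meant among the compounds shown, and "the series" means these compounds.

Measured so far:
Compound 1, `CC(=O)OC(C)n1cnc2c(Cl)nc(I)nc21`, in a functional assay on SW-620 cells (Homo sapiens) for inhibition (a higher number here means a weaker inhibitor, a lower number a stronger inhibitor), compound 1 gives 3550 nM.
Compound 2, `CC(=O)OCCOn1cnc2c(Cl)nc(I)nc21`, gives 15800 nM.
Compound 3, `CC(=O)OC(C)n1cnc2c(Cl)nc(F)nc21`, gives 8900 nM.

Among these three numbers compound 3 has the second highest. Its nearest neighbour is compound 2, whose number is higher but within the scatter, so the two cannot be told apart. Within the data shown here, its furthest neighbour is compound 1: the only single-point step among the measured compounds, a 2.5-fold higher number from compound 1 to compound 3 (0.40 log units; beyond the scatter), lies beyond the scatter and goes with fluoro in place of iodo on an aromatic carbon.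

Compound 4, `CC(=O)OC(C)n1cnc2c(S)nc(F)nc21`, is made from compound 3 by a different change: sulfanyl in place of chloro on an aromatic carbon. Among the measured compounds shown here, no measured step swaps chloro for sulfanyl, and the one step that is known concerns another position and another pair of groups, so it offers only a sense of scale, not a direction. The expectation is therefore a step of modest size at most, a 1.1-fold higher number from compound 3 to compound 4 (0.05 log units; within the scatter), with the direction open. For compound 4 the estimate in this assay is 10000 nM, expected to fall between 3000 nM and 35000 nM.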

Compound 4, half-maximal inhibitory concentration: > 500000 nM
Compound 4 was reported as a limit; the forecaster's own chance of this, stated with the estimate: 10%; middle value at least 50-fold (1.69 log units) away from the limit.
By their numbers in this assay, from the lowest: compound 1; then compounds 3 and 2 (each within the scatter of the next). At a limit, above all of these: compound 4.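

Among these compounds, until now the only single-point step was a modest one involving the fluoro and iodo groups, but the aromatic carbon next to the ring nitrogen proves far more sensitive: sulfanyl in place of chloro gives an at least 56-fold higher number from compound 3 to compound 4 (1.74 log units; beyond the scatter) in this assay. Compound 4 is reported only as a limit, so this step sets a floor on the size of the change and does not give its true size: the limit of > 500000 nM in this assay, at which 1 of the 4 values shown sits. Chloro and sulfanyl each count as 1 heavy atom, and sulfanyl alone brings 1 hydrogen-bond donor and 1 hydrogen-bond acceptor, so a swap that leaves the heavy-atom count unchanged can still go with a large step.

The compounds shown leave open whether the step follows from losing chloro or from gaining sulfanyl, and how an amine, a methoxy group or a methylsulfanyl group on this carbon would compare. Also open is whether the step would be as large with iodo in place of fluoro; the only sulfanyl compound shown carries fluoro.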